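Series notes: quinolinol ethers and esters, cytotoxicity on HCT-8

The source may report more compounds than this note shows. Statements on the series, on what has been measured and on what is new or still open speak of the compounds shown alone.

The series is followed in a functional assay on HCT-8 cells (Homo sapiens) for cytotoxicity; on this read-out lower numbers stand for an effect already at smaller amounts and higher numbers for an effect only at larger amounts of compound. Compound 1 `Oc1ccc2nc(-c3ccccc3)cc(O)c2c1` gives 7.75 ug/mL. Compound 3 `Oc1cc(-c2ccccc2)nc2c(F)cccc12` gives 0.04 ug/mL. Compound 2 `CC(C)COc1cc(-c2ccccc2)nc2ccccc12` reaches only a limit of this assay, reported as > 10 ug/mL, so compound 2 stands at the limit of > 10 ug/mL in this assay, at which 1 of the 3 values shown sits, and no number is known for it. Compound 4 `CS(=O)(=O)Oc1cc(-c2ccccc2)nc2ccccc12` differs from compound 2 by methylsulfonyl in place of isobutyl on an oxygen on an aromatic ring. For the measured compounds named here, no measured step between two compounds that differ in one place is available, so the size of this change cannot be read from the data. The step from compound 2 to compound 4 is expected to be an at least 1.2-fold lower number from compound 2 to compound 4 (0.09 log units; that floor lies within the scatter), that is, none beyond the scatter or a small move toward smaller amounts. Compound 4 is therefore estimated at 8 ug/mL, within 1.5 ug/mL to 30 ug/mL.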

Compound 4, half-maximal effective concentration: 5.6 ug/mL
For compound 4 the middle estimate is 1.4-fold (0.15 log units) above the measured one; low and high end bracket the measured number.
By their numbers in this assay, from the lowest: compound 3; then compounds 4 and 1 (each within the scatter of the next). At a limit, above all of these: compound 2.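

In this assay, methylsulfonyl in place of isobutyl on an oxygen on an aromatic ring gives the first step readable in the series: an at least 1.7-fold lower number from compound 2 to compound 4 (0.25 log units; that floor lies within the scatter). Only the floor of this step is known, so the change may be small or considerably larger. Compound 2 stays a limit and not a number: the limit of > 10 ug/mL in this assay, at which 1 of the 4 values shown sits.

On these data alone, how an acetyl group or a longer chain on the same oxygen would read remains open. So does whether the step holds on the cores of compound 1 and compound 3.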